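Chloro to Hydroxy in a Cytotoxic Series

The compounds below may be only part of what the source reports. "The series", "measured", "known", "first", "only" and "open" are said of these compounds alone.

In a functional assay on SW-620 cells (Homo sapiens) for cytotoxicity, read by MTT assay, with a stated time of 72 h (a higher number here means a weaker inhibitor, a lower number a stronger inhibitor), compound 1 `COc1ccc(/C=C2\CCC/C(=C\c3cccc(OC)c3OC)C2=O)cc1OC` gives 6400 nM, compound 2 `COc1cc(/C=C2\CCC/C(=C\c3cccc(OC)c3OC)C2=O)ccc1O` gives 8600 nM and compound 3 `COc1ccc(/C=C2\CCC/C(=C\c3cccc(Cl)c3)C2=O)cc1OC` gives 5100 nM, so all three lie within the usual scatter of one another. Compound 4 `COc1ccc(/C=C2\CCC/C(=C\c3cccc(O)c3)C2=O)cc1OC` carries hydroxy in place of the chloro of compound 3 on an aromatic carbon: hydroxy in place of chloro on an aromatic carbon. Among the measured compounds shown here, the only measured step that also produces a hydroxy is a 1.3-fold higher number from compound 1 to compound 2 (0.13 log units; within the scatter), where hydrogen replaces methyl on an oxygen on an aromatic ring. For the measured compounds named here, no measured pair swaps chloro for hydroxy, so this is thin evidence, and no shift beyond the scatter is expected in this assay. The expected size is a 1.2-fold higher number from compound 3 to compound 4 (0.07 log units; within the scatter). Compound 4 is estimated at 6000 nM, with a range of 2500 nM to 14000 nM.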

Compound 4, half-maximal inhibitory concentration: 1900 nM
For compound 4 the middle estimate is 3.2-fold (0.50 log units) above the measured one, and the stated range ends above it.
By their numbers in this assay, from the lowest: compound 4; then compounds 3, 1 and 2 (each within the scatter of the next).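

Among the compounds shown here, the one earlier step, which also produced a hydroxy, stayed within the scatter, whereas swapping chloro for hydroxy at this place on the ring gives a 2.7-fold lower number from compound 3 to compound 4 (0.43 log units; beyond the scatter) in this assay. This position, meta to a large group, therefore responds to what it carries, and compound 4 has the lowest number of the four. Nothing available explains this shift.

As far as these compounds go, it remains open how an amine or a carboxylic acid at this position would compare with hydroxy. From the compounds shown here alone, this is also a single pair, so whether the swap has the same effect with other groups on the second aromatic ring is unknown.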